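This account rests on a few compounds, and the source may have more. Where it says the series, first, only, none or still open, it means among the compounds named here.

In a functional assay on SK-MEL-28 cells (Homo sapiens) for antiproliferative activity, read by sulforhodamine B assay, with a stated time of 48 h (on this read-out lower numbers stand for stronger inhibition and higher numbers for weaker inhibition), compound 1 `Nc1cccc2c(-c3cccc(NC(=O)c4ccc(Cl)c(C(F)(F)F)c4)c3)ccnc12` gives 2900 nM, while compound 2 `Nc1cccc2c(-c3cccc(NC(=O)c4ccc5c(c4)OCCO5)c3)ccnc12` gives 85 nM. Compound 2 therefore holds the lowest of the two numbers, with compound 1 the nearest at a gap that lies beyond the usual scatter. Compound 3 `Nc1cccc2c(-c3cccc(NC(=O)c4nccs4)c3)ccnc12` differs from compound 2 by 1,3-thiazol-2-yl in place of 2,3-dihydro-1,4-benzodioxin-6-yl on a carbonyl carbon. Within the data shown here, no measured pair shows this change, so its size rests on the two numbers alone. In this assay the step is expected to raise the number, a 4.7-fold higher number from compound 2 to compound 3 (0.67 log units; beyond the scatter). Compound 3 is estimated at 400 nM, within a range from 80 nM to 2500 nM.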

Compound 3, half-maximal inhibitory concentration: 15800 nM
Compound 3: middle estimate off by 40-fold (1.60 log units), on the low side; measured number above the stated range.
By their numbers in this assay, from the lowest: compound 2; then compound 1; then compound 3.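

In this assay the group on the carbonyl carbon now has a measured step: 1,3-thiazol-2-yl in place of 2,3-dihydro-1,4-benzodioxin-6-yl gives a 190-fold higher number from compound 2 to compound 3 (2.27 log units; beyond the scatter), with the rest of the structure unchanged. This position therefore does not treat these two ring groups alike, and the read-out responds strongly to the exchange. No measurement at hand accounts for the size of this step.

The compounds shown leave open whether the loss follows from the five-membered ring with its sulfur and nitrogen or from the absence of the fused oxygen-bearing ring. A plain phenyl or a 1,3-benzodioxol-5-yl group on the same carbonyl carbon would help separate these two readings.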